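A few compounds are considered here, and "the series" means these few. Any claim that something is new, unique, unknown or untested is made for them only; others in the source may bear on it.

In a functional assay on CH1 cells (Homo sapiens) for inhibition, read by sulforhodamine B assay, with a stated time of 96 h (on this read-out lower numbers stand for stronger inhibition of growth and higher numbers for weaker inhibition of growth), compound 2 `CC[C@@H](Nc1nc(NCc2ccccn2)c2ncn(C(C)C)c2n1)C(O)C(C)(C)C` gives 34000 nM and compound 1 `CC[C@@H](Nc1nc(NCc2ccccn2)c2ncn(C(C)C)c2n1)C(C)O` gives 20000 nM, so these two values sit within the scatter of each other. Compound 3 `CCC(O)[C@H](CC)Nc1nc(NCc2ccccn2)c2ncn(C(C)C)c2n1` carries 1-ethyl-2-hydroxybutyl in place of the 1-ethyl-2-hydroxy-3,3-dimethylbutyl of compound 2, on a nitrogen on an aromatic ring: 1-ethyl-2-hydroxybutyl in place of 1-ethyl-2-hydroxy-3,3-dimethylbutyl on a nitrogen on an aromatic ring. Within the data shown here, the only measured step that alters this same side chain is a 1.7-fold higher number from compound 1 to compound 2 (0.23 log units; within the scatter), and it stayed within the scatter. No change beyond the scatter is therefore expected in this assay, and the expected move is a 1.4-fold lower number from compound 2 to compound 3 (0.13 log units; within the scatter). Compound 3 is estimated at 25000 nM, with a range of 12000 nM to 50000 nM.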

Compound 3, concentration for 50% growth inhibition: 33000 nM
Beside the measured number, compound 3's estimate is 1.3-fold (0.12 log units) below it; measured number inside the range.
By their numbers in this assay, from the lowest: compounds 1, 3 and 2 (each within the scatter of the next).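

Compound 3 adds a third side chain on this nitrogen on an aromatic ring, and in this assay the three remain within the scatter of each other. 1-Ethyl-2-hydroxybutyl in place of 1-ethyl-2-hydroxy-3,3-dimethylbutyl gives a 1.0-fold lower number from compound 2 to compound 3 (0.01 log units; within the scatter), and in place of 1-(1-hydroxyethyl)propyl it gives a 1.7-fold higher number from compound 1 to compound 3 (0.22 log units; within the scatter), so among these three compounds, methyl, ethyl and tert-butyl at the end of the chain are not told apart. Nothing available here accounts for this flat result. On these data alone, whether a chain ending in an amine or a carboxylic acid instead of the hydroxyl would shift the number remains open.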